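Trading 3-hydroxyphenyl for 2-fluorophenyl on the amide

A few compounds are considered here, and "the series" means these few. Any claim that something is new, unique, unknown or untested is made for them only; others in the source may bear on it.

Three measured compounds share one core and differ only in the aromatic group on an amide-type nitrogen. In a functional assay on SiHa cells (Homo sapiens) for inhibition, read by CCK-8 assay, with a stated time of 72 h, tested at 1 uM (a higher number here means more inhibition of growth at the concentration tested, a lower number less inhibition of growth), compound 1 (`CN(C)C(=O)c1cc2cnc(Nc3ccc(NC(=O)C4(C(=O)Nc5ccc(Cl)cc5)CC4)cc3)nc2n1C1CCCC1`), with 4-chlorophenyl, gives -0.8% as its result. Compound 2 (`CN(C)C(=O)c1cc2cnc(Nc3ccc(NC(=O)C4(C(=O)Nc5cccc(F)c5)CC4)cc3)nc2n1C1CCCC1`), with 3-fluorophenyl, gives 29.7% in the same test. Compound 3 (`CN(C)C(=O)c1cc2cnc(Nc3ccc(NC(=O)C4(C(=O)Nc5cccc(O)c5)CC4)cc3)nc2n1C1CCCC1`), with 3-hydroxyphenyl, gives -19.8% and stands lowest of the three.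

Compound 4 (`CN(C)C(=O)c1cc2cnc(Nc3ccc(NC(=O)C4(C(=O)Nc5ccccc5F)CC4)cc3)nc2n1C1CCCC1`) is still unmeasured. Its difference from compound 3 is 2-fluorophenyl in place of 3-hydroxyphenyl on an amide-type nitrogen and amounts to 2-fluorophenyl in place of 3-hydroxyphenyl on an amide-type nitrogen.

The closest guide is hydroxy in place of fluoro on an aromatic carbon, which gave a number 49.5 percentage points lower from compound 2 to compound 3 (beyond the scatter) as a large step. Two further steps frame it: 3-hydroxyphenyl in place of 4-chlorophenyl gave a number 19 percentage points lower from compound 1 to compound 3 (beyond the scatter) as a modest step, and 3-fluorophenyl in place of 4-chlorophenyl gave a number 30.5 percentage points higher from compound 1 to compound 2 (beyond the scatter) as a large one. Among the measured compounds shown here, no measured compound carries 2-fluorophenyl, so the fluoro comparison is only partial. A rise is expected, probably short of the full distance up to compound 2, with the estimated step being a number 31.8 percentage points higher from compound 3 to compound 4 (beyond the scatter) in this assay on this reasoning. For compound 4 the estimated result is 12% within an expected range of -12% to 38% at the concentration tested.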

Compound 4, percent growth inhibition at one concentration: 63.4%
Estimate against measurement, compound 4: 51.4 percentage points below, outside the stated range (above it).
By their numbers in this assay, from the lowest: compound 3; then compound 1; then compound 2; then compound 4.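

In this assay, the step from 3-fluorophenyl to 2-fluorophenyl on the amide-type nitrogen is large (a number 33.7 percentage points higher from compound 2 to compound 4 (beyond the scatter)), which shows that the position of the fluoro on this ring matters as well as its presence. The same 2-fluorophenyl group also stands well clear of the other two aryl groups, both against 3-hydroxyphenyl (a number 83.2 percentage points higher from compound 3 to compound 4 (beyond the scatter)) and against 4-chlorophenyl (a number 64.2 percentage points higher from compound 1 to compound 4 (beyond the scatter)), making compound 4 the most growth-inhibiting of the four at the concentration tested, with every step to it beyond the usual scatter. The data shown give no account of why this swap has so large an effect.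

The compounds shown leave open whether the gain belongs to fluoro itself or would also appear with another group at the same place on the ring, such as a methyl, a methoxy or an amine. With one reading at one concentration in one cell line, they also cannot say how compound 4 would behave across a range of concentrations or in other cells.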